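The source may report more compounds than this note shows. Statements on the series, on what has been measured and on what is new or still open speak of the compounds shown alone.

Series notes. For the measured compounds named here, compound 3 `COc1ccc2nc(NC(=O)c3cc(-c4ccc(F)cc4)n4nc(-c5ccccc5)cc4n3)sc2c1` is the weakest of the three measured members in a functional assay on A549 cells (Homo sapiens) for cytotoxicity, read by MTT assay, with a stated time of 48 h; on this read-out lower numbers stand for stronger inhibition and higher numbers for weaker inhibition: compound 3 gives 24000 nM. Going by the values given here, compound 1 `COc1ccc(-c2cc(C(=O)Nc3nc4ccc(Cl)cc4s3)nc3cc(-c4ccccc4)nn23)cc1` gives 3090 nM in this assay and compound 2 `COc1ccc(-c2cc(C(=O)Nc3nc4ccc(F)cc4s3)nc3cc(-c4ccccc4)nn23)cc1` gives 11700 nM; the only single-point step among them, a 3.8-fold higher number from compound 1 to compound 2 (0.58 log units; beyond the scatter), sits on the benzothiazole end of the shared core.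

Compound 4 `COc1ccc(-c2cc(C(=O)Nc3nc4ccc(OC)cc4s3)nc3cc(-c4ccccc4)nn23)cc1` differs from compound 3 at the other end: methoxy in place of fluoro on an aromatic carbon. Among the compounds with values here, no measured pair changes this group at this place, so the step from compound 1 to compound 2 does not bear on it directly; it shows only that a single substituent swap on this scaffold can move the number modestly. Compounds 1 and 2 both carry the 4-methoxyphenyl and both sit lower than compound 3, which is the only indirect hint available.

The estimate is therefore a modest move toward stronger inhibition, a 2.0-fold lower number from compound 3 to compound 4 (0.30 log units; within the scatter), so that compound 4 is expected to give about 12000 nM in this assay, with a range from 4000 nM to 40000 nM.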

Compound 4, half-maximal inhibitory concentration: 17400 nM
The estimate for compound 4 lay 1.5-fold (0.16 log units) below the measured number; the range from low to high includes it.
By their numbers in this assay, from the lowest: compound 1; then compounds 2, 4 and 3 (each within the scatter of the next, the first and the last beyond it).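

In this assay, for the compounds shown here, the change from 4-fluorophenyl to 4-methoxyphenyl gives the first direct reading at this position, and a 1.4-fold lower number from compound 3 to compound 4 (0.14 log units; within the scatter) does not separate the two groups. With the 4-methoxyphenyl held constant, methoxy in place of fluoro on the other end of the shared core also stays inside the scatter in a 1.5-fold higher number from compound 2 to compound 4 (0.17 log units; within the scatter) while methoxy in place of chloro does not in a 5.6-fold higher number from compound 1 to compound 4 (0.75 log units; beyond the scatter), so among chloro, fluoro and methoxy at that place only chloro stands apart. The compounds shown offer no independent measurement that explains either outcome.

On these data alone, whether chloro keeps its lower number when paired with 4-fluorophenyl remains open. So does the outcome for an amine, a carboxylic acid or a longer alkoxy chain at either place.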